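Sulfonate Adduct of the Propyl Carbamate: Cytotoxicity Notes

The source may hold more compounds than are shown below. What is called first, only, known or untested is meant among the compounds shown, and "the series" means these compounds.

Compound 1 `CC(C)C[C@H](NC(=O)OC(c1ccccc1)C1CCC(F)(F)CC1)C(=O)N[C@H](C=O)C[C@@H]1CCNC1=O` carries a formyl group on the shared core. In an ADME assay on HEK-293T cells (Homo sapiens) for cytotoxicity, with a stated time of 72 h (on this read-out lower numbers stand for higher toxicity in this test and higher numbers for lower toxicity in this test), compound 1 gives > 100000 nM, which is a limit of the assay and not a number. Compound 2 `CC(C)C[C@H](NC(=O)OC(c1ccccc1)C1CCC(F)(F)CC1)C(=O)N[C@@H](C[C@@H]1CCNC1=O)C(O)S(=O)(=O)O` differs from it by hydroxy(sulfo)methyl in place of formyl on a saturated chain carbon bound to an amide-type nitrogen and a saturated chain carbon. In this assay compound 2 gives > 100000 nM, again only a limit. The step that the two limits leave unreadable from compound 1 to compound 2 therefore cannot be sized. Compound 3 `CCCC(OC(=O)N[C@@H](CC(C)C)C(=O)N[C@H](C=O)C[C@@H]1CCNC1=O)c1ccccc1` differs from compound 1 by propyl in place of 4,4-difluorocyclohexyl on a saturated chain carbon bound to an aromatic carbon and an oxygen next to a carbonyl group; this is how the two cores differ. In this assay compound 3 gives > 100000 nM, a limit as well. The step that the two limits leave unreadable from compound 1 to compound 3 is likewise not readable. The single fixed point of the series is the limit of > 100000 nM in this assay, at which 3 of the 3 values shown sit.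

Among the compounds with values here, compound 4 `CCCC(OC(=O)N[C@@H](CC(C)C)C(=O)N[C@@H](C[C@@H]1CCNC1=O)C(O)S(=O)(=O)O)c1ccccc1` is not yet measured; it differs from compound 3 by hydroxy(sulfo)methyl in place of formyl on a saturated chain carbon bound to an amide-type nitrogen and a saturated chain carbon, the same change as the one from compound 1 to compound 2. Compound 4 is expected to give 150000 nM in this assay, within 100000 nM to 300000 nM, and most probably to be reported only as a limit. For compound 4 the expected step that the limit leaves unreadable from compound 3 to compound 4 rests on compound 1 and compound 2 both sitting at the limit of > 100000 nM in this assay, at which 3 of the 3 values shown sit, so that the change has left no readable mark in this test. Within the data shown here, no pattern beyond these compounds is claimed.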

Compound 4, half-maximal cytotoxic concentration: > 100000 nM
Compound 4: only a limit was reported; the forecaster's own chance of this, stated with the estimate: 90%; the middle value does not contradict the limit.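

In this assay no step can be read among compound 1, compound 2, compound 3 and compound 4, neither for hydroxy(sulfo)methyl in place of formyl nor for propyl in place of 4,4-difluorocyclohexyl, and each value is a limit and not a number: the limit of > 100000 nM in this assay, at which 4 of the 4 values shown sit.

The compounds shown leave open whether either change alters cytotoxicity in this test, and how far any of the four compounds lies from that limit.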